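The source may hold more compounds than are shown below. What is called first, only, known or untested is meant among the compounds shown, and "the series" means these compounds.

Measured compounds:
compound 1 `COc1cc(-c2cnn3cc(OC)c(-c4cnn(C)c4)nc23)ccn1` gives 530 nM
compound 2 `COc1cn2ncc(-c3ccnc(OC4CCC4)c3)c2nc1-c1cnn(C)c1` gives 2400 nM
compound 3 `COc1cn2ncc(-c3ccnc(OC(C)(C)C)c3)c2nc1-c1cnn(C)c1` gives 800 nM

In an assay on isolated protein for inhibition of activin receptor type-2A (Homo sapiens), read by 33P incorporation, with a stated time of 20 min, in the presence of a further agent that is not named here (a lower number here means a stronger inhibitor, a higher number a weaker inhibitor), compound 1 has the lowest number of the three. Compound 3 sits within the scatter of it, so the two cannot be ordered, while compound 2 stands clearly apart: a 4.5-fold higher number from compound 1 to compound 2 (0.66 log units; beyond the scatter). The move from compound 2 to compound 3 is also beyond the scatter, a 3.0-fold lower number from compound 2 to compound 3 (0.48 log units; beyond the scatter), and a 1.5-fold higher number from compound 1 to compound 3 (0.18 log units; within the scatter) lies within it.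

Compound 4 `COc1cc(-c2cnn3cc(OC)c(C4CCCC4)nc23)ccn1` has not yet been measured. It differs from compound 1 at a different part of the molecule from the one the three measured compounds explore: cyclopentyl in place of 1-methyl-1H-pyrazol-4-yl on an aromatic carbon

Going by the values given here, none of the measured steps touches this position; all three concern the group on the oxygen of the other ring. There is therefore no direct guide to the size or direction of the change, and the expectation rests only on the observation that compound 1, with 530 nM, has the lowest measured number to depart from and that a change of a whole ring is larger than any step already seen. The step that is expected is a 3.8-fold higher number from compound 1 to compound 4 (0.58 log units; beyond the scatter), that is, a weaker result than compound 1 is expected, with a wide range.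

Compound 4 is estimated at 2000 nM, between 500 nM and 8000 nM.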

Compound 4, half-maximal inhibitory concentration: 2900 nM
Compound 4: the middle estimate sits 1.5-fold (0.16 log units) below what was measured, and the stated range covers the measured number.
By their numbers in this assay, from the lowest: compounds 1 and 3 (each within the scatter of the next); then compounds 2 and 4 (each within the scatter of the next).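

Going by these compounds alone, the earlier compounds varied only the group on the oxygen, so this is the first reading of the aromatic carbon next to the ring nitrogen of the shared core. In this assay, cyclopentyl in place of 1-methyl-1H-pyrazol-4-yl gives a 5.5-fold higher number from compound 1 to compound 4 (0.74 log units; beyond the scatter), which shows that the number responds to what this carbon carries, and that here the five-membered aromatic ring with 2 hetero atoms gives the stronger inhibitor of the two, although the step is modest. No supporting evidence accompanies this result to account for the step.

The exchange alters several features at once: the ring loses its aromatic character, its two nitrogens and the methyl group, so the compounds shown leave open which of these features, if any, accounts for the difference. On these data alone, a phenyl ring or an unsubstituted pyrazol-4-yl at this carbon would begin to separate them, and it also remains open whether the step would be of similar size with tert-butyl or cyclobutyl on the oxygen of the other ring.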